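A few compounds are considered here, and "the series" means these few. Any claim that something is new, unique, unknown or untested is made for them only; others in the source may bear on it.

Measured so far in a functional assay on A549 cells (Homo sapiens) for cytotoxicity, read by MTT assay, with a stated time of 24 h; a higher number here means a weaker inhibitor, a lower number a stronger inhibitor:
- compound 1 `C#CCn1c(=O)c(C=O)cc2ccccc21` gives > 100000 nM (a limit)
- compound 2 `C#CCn1c(=O)c(C=O)cc2cc(C)ccc21` gives > 100000 nM (a limit)
- compound 3 `C=CCn1c(=O)c(/C=C/C(=O)/C=C(O)/C=C/c2ccc(O)c(OC)c2)cc2ccccc21` gives 31300 nM

Compound 3 is the only one of these with a number, as the other two stand at a limit (the limit of > 100000 nM in this assay, at which 2 of the 3 values shown sit).

Compound 4 `C#CCn1c(=O)c(/C=C/C(=O)/C=C(O)/C=C/c2ccc(O)c(OC)c2)cc2ccccc21` departs from compound 3 in one place (ethynyl in place of vinyl on a saturated chain carbon bound to an aromatic nitrogen): ethynyl in place of vinyl on a saturated chain carbon bound to an aromatic nitrogen, or allyl to propargyl when cut one bond further out. Going by the values given here, the one measured step (a step that the two limits leave unreadable from compound 1 to compound 2) is a different change and gives no size to carry over. Among the compounds with values here, compound 1 and compound 2 carry the propargyl group but also differ from compound 3 elsewhere, so no measured pair isolates this change. In this assay no step beyond the usual scatter is therefore expected, in either direction. The expected step is small (a 1.0-fold lower number from compound 3 to compound 4 (0.02 log units; within the scatter)). This expectation rests on compound 3 at 31300 nM and on the modest size of the change. Compound 4 is estimated at 30000 nM (expected range 12000 nM to 80000 nM).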

Compound 4, half-maximal inhibitory concentration: 21300 nM
Beside the measured number, compound 4's estimate is 1.4-fold (0.15 log units) above it, and the stated range covers the measured number.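

In this assay, going from allyl to propargyl on the saturated chain carbon bound to an aromatic nitrogen gives a 1.5-fold lower number from compound 3 to compound 4 (0.17 log units; within the scatter), so this position accepts ethynyl in place of vinyl with no step beyond the scatter. Going by these compounds alone, this is the first readable step, as the methyl step between compound 1 and compound 2 cannot be read: the limit of > 100000 nM in this assay, at which 2 of the 4 values shown sit. Compound 4 carries the propargyl group and still gives a number, 21300 nM, not a limit.

Open, on these data alone, is whether a longer chain such as butyl, or a chain ending in an amine, at this same place would give a step beyond the scatter. Also open, as far as these compounds go, is whether methyl on an aromatic carbon of the core gives a readable step in compounds with the longer side chain of compound 3.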